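A Piperidine in Place of an Oxetane on a Shared Core

The source may hold more compounds than are shown below. What is called first, only, known or untested is meant among the compounds shown, and "the series" means these compounds.

Of the compounds shown here, three sharing one core have been measured in a functional assay on KARPAS-299 cells (Homo sapiens) for inhibition, read by CellTiter-Glo, with a stated time of 96 h; on this read-out lower numbers stand for stronger inhibition and higher numbers for weaker inhibition. Compound 1 `Cc1cc(Nc2ncc(Cl)c(Nc3cn(C)nc3S(=O)(=O)C(C)C)n2)c(OC2CC2)cc1C1COC1` gives 19 nM in this assay, the lowest of the three numbers. Compound 2 `Cc1cc(Nc2ncc(Cl)c(Nc3cn(C)nc3S(=O)(=O)C(C)C)n2)c(OC(C)C)cc1C1CCNC1` gives 28 nM in this assay, which lies within the usual scatter of the value of compound 1, so the two cannot be told apart. Compound 3 `Cc1cc(Nc2ncc(Cl)c(Nc3cn(C)nc3S(=O)(=O)C(C)C)n2)c(C(F)(F)F)cc1C1CCN(C)CC1` gives 74 nM in this assay, and here the gap to compound 1 lies beyond the scatter.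

Compound 4 `Cc1cc(Nc2ncc(Cl)c(Nc3cn(C)nc3S(=O)(=O)C(C)C)n2)c(OC2CC2)cc1C1CCCN(C)C1` has not yet been measured. It differs from compound 1 in one place: 1-methylpiperidin-3-yl in place of oxetan-3-yl on an aromatic carbon. The cyclopropyloxy group and the methyl group of compound 1 are kept, and only the group para to the large group is exchanged.

Because compound 2, which carries a pyrrolidin-3-yl group on the same carbon, gives 28 nM in this assay, a nitrogen-containing saturated ring at this place appears to be tolerated. Compound 3 carries a 1-methylpiperidin-4-yl group and gives 74 nM in this assay, but it also differs in the cyclopropyloxy position, so its number is not a clean guide.

Compound 4 is therefore expected to give a value near compound 1, with a step of a 1.4-fold higher number from compound 1 to compound 4 (0.14 log units; within the scatter) that is expected to stay within the scatter or at most slightly weaker. The estimate for compound 4 in this assay is 26 nM, expected to fall between 10 nM and 70 nM.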

Compound 4, half-maximal inhibitory concentration: 3 nM
Compound 4: middle estimate off by 8.7-fold (0.94 log units), on the high side; measured number outside the range, below it.
By their numbers in this assay, from the lowest: compound 4; then compounds 1 and 2 (each within the scatter of the next); then compound 3.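

With the rest of the molecule unchanged, replacing oxetan-3-yl with 1-methylpiperidin-3-yl on this aromatic carbon in this assay gives a 6.3-fold lower number from compound 1 to compound 4 (0.80 log units; beyond the scatter). This single-place comparison shows that the position, ortho to a methyl group and meta to a cyclopropyloxy group, accommodates the six-membered ring and that the value responds to this exchange, which compounds 2 and 3 could not show, as each differs from compound 1 in more than one place. The data shown offer no independent measurement that accounts for the size of this step.

The exchange alters the ring size, the hetero atom and the substitution together, so the compounds shown leave open which of these changes accounts for the step, a question that a cyclohexyl group or a piperidin-3-yl group lacking the methyl group on nitrogen would address on the same core. They also leave open whether a comparable step would appear with an isopropoxy group in place of the cyclopropyloxy group, or with a 1-methylpiperidin-4-yl group at this position on the core of compound 1.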